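A few compounds are considered here, and "the series" means these few. Any claim that something is new, unique, unknown or untested is made for them only; others in the source may bear on it.

Measured compounds:
compound 1, `N#Cc1ccnc(Oc2nn(C3CCC3)c3ncnc(N)c23)c1`: 2.35 h
compound 2, `Nc1ncnc2c1c(Oc1cc(C(F)(F)F)ccn1)nn2C1CCC1`: 1.02 h
compound 3, `Nc1ncnc2c1c(Oc1cc(Cl)ccn1)nn2C1CCC1`: 0.333 h

These three share one core and differ only in the group on the pyridine carbon. In an ADME assay on microsomes from liver (Homo sapiens) for metabolic stability, read by LC-MS, using NADPH, with a stated time of 10 min, tested at 10 uM (on this read-out higher numbers stand for a longer-lived compound and lower numbers for a shorter-lived compound), compound 1 gives 2.35 h, compound 2 gives 1.02 h and compound 3 gives 0.333 h. Compound 3 stands lowest of the three: the nearest number is that of compound 2, seen in a 3.1-fold lower number from compound 2 to compound 3 (0.49 log units; beyond the scatter), and the furthest is that of compound 1, seen in a 7.1-fold lower number from compound 1 to compound 3 (0.85 log units; beyond the scatter). The remaining measured step is a 2.3-fold lower number from compound 1 to compound 2 (0.36 log units; beyond the scatter).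

Compound 4, `Nc1ncnc2c1c(Oc1cc(Cl)ccn1)nn2[C@H]1C[C@H](F)C1`, is not yet measured. It differs from compound 3 in one place: fluoro in place of hydrogen on a saturated ring carbon. Every measured step here concerns the aromatic carbon of the pyridine; none touches the four-membered ring. Among the measured compounds shown here, no measured step therefore bears on this change, and the expectation for compound 4 can rest only on the value of compound 3. Compound 4 is accordingly expected to show a step of about a 1.2-fold higher number from compound 3 to compound 4 (0.08 log units; within the scatter), that is, none beyond the scatter in either direction. Compound 4 is estimated at 0.4 h, with a range from 0.17 h to 0.95 h.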

Compound 4, half-life: 0.833 h
Compound 4: middle estimate off by 2.1-fold (0.32 log units), on the low side; the range from low to high includes it.
By their numbers in this assay, from the lowest: compound 3; then compounds 4 and 2 (each within the scatter of the next); then compound 1.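

In this assay, among the compounds shown here, the change from cyclobutyl to 3-fluorocyclobutyl gives a 2.5-fold higher number from compound 3 to compound 4 (0.40 log units; beyond the scatter), the first measured step on the four-membered ring rather than on the pyridine carbon. It shows that, with chloro held on the pyridine, a single fluoro on this saturated ring carbon raises the half-life beyond the scatter, so the ring is a second place where this number can change. Nothing shown here accounts for the rise.

The compounds shown hold this fluoro only alongside chloro, so whether the step would be similar with nitrile or trifluoromethyl on the pyridine carbon stays open. Also open, from the compounds shown here alone, is how the half-life would respond to the other stereoisomer of the fluoro compound, or to a hydroxyl, an amine or a second fluoro on this ring carbon.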